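Three chalcones measured, a fourth awaits its number

The compounds below may be only part of what the source reports. "The series", "measured", "known", "first", "only" and "open" are said of these compounds alone.

Of the compounds shown here, three built on a shared core have been measured in a functional assay on PC-3 cells (Homo sapiens) for cytotoxicity, with a stated time of 48 h; a lower number here means a stronger inhibitor, a higher number a weaker inhibitor. Compound 1, `COc1cc(O)c(C(=O)/C=C/c2ccc(F)cc2)c(OC)c1`, gives 13200 nM. Compound 2, `COc1cc(OC)c(C(=O)/C=C/c2ccc(Cl)cc2)c(OC)c1`, gives 5800 nM. Compound 3, `COc1cccc(/C=C/C(=O)c2c(O)cc(OC)cc2OC)c1`, gives 7300 nM. Among these three numbers compound 2 has the lowest; its nearest neighbour is compound 3, whose number is within the usual scatter of that of compound 2, so no order between those two can be read. Compound 1 lies furthest away, and its gap from compound 2 is beyond the scatter.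

The account now turns to compound 4, `COc1cc(OC)c(C(=O)/C=C/c2ccccc2SC)c(OC)c1`, which has not yet been measured in this assay. It differs from compound 2 in one place: 2-(methylsulfanyl)phenyl in place of 4-chlorophenyl on a double-bonded chain carbon bound to a double-bonded chain carbon. Going by the values given here, no pair of measured compounds shows the effect of this particular change, so the size and direction of the step cannot be taken from the numbers available. The change is expected to bring no step beyond the scatter, with a mild leaning toward a slightly higher number, which means a step of a 1.3-fold higher number from compound 2 to compound 4 (0.11 log units; within the scatter) is estimated. For compound 4 in this assay the estimate is 7500 nM, with a range from 2500 nM to 22000 nM.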

Compound 4, half-maximal inhibitory concentration: 7600 nM
For compound 4 the middle estimate is 1.0-fold (0.01 log units) below the measured one, within the range that was stated.
By their numbers in this assay, from the lowest: compounds 2, 3, 4 and 1 (each within the scatter of the next, the first and the last beyond it).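

In this assay, going by these compounds alone, putting 2-(methylsulfanyl)phenyl in place of 4-chlorophenyl on a double-bonded chain carbon bound to a double-bonded chain carbon gives a 1.3-fold higher number from compound 2 to compound 4 (0.12 log units; within the scatter), the first step that can be read at this place. The step shows that, in this one pair, the exchange of a chlorine-bearing group for a sulfur-bearing one, with 8 heavy atoms instead of 7 and 1 hydrogen-bond acceptor instead of 0, leaves the two numbers within the scatter of each other, so no order between compound 2 and compound 4 can be read. No other measurement is available that would help interpret this result.

The compounds shown cannot separate the identity of the new group from the place it occupies on its ring, and a single pair cannot tell whether other groups at this place would also stay within the scatter. From the compounds shown here alone, whether a carboxylic acid or an amine on this ring would give a step beyond the scatter remains open, as does whether the same exchange would give a similar step on the core of compound 1 or compound 3.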